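Series notes: replacing the protected side chain by isopropyl

A few compounds are considered here, and "the series" means these few. Any claim that something is new, unique, unknown or untested is made for them only; others in the source may bear on it.

Compound 2 `CC(C)(C)OC(=O)NCCCC[C@H](NC(=O)CN(c1ncnc2c1ncn2C1CCCCO1)C1CC1)C(=O)OCc1ccccc1` gives 32.7% in a functional assay on the whole organism (Tail, strain ICR) with Mus musculus as the target, in the tail flick test, with a stated time of 60 min, at a dose of 25 umol/kg by the oral route (a lower number here means a weaker effect, a higher number a stronger effect of the compound at the dose given), and stands lowest of the two numbers measured. Compound 1 `C[C@H](NC(=O)CN(c1ncnc2c1ncn2C1CCCCO1)C1CC1)C(=O)OCc1ccccc1` gives 53%. For the measured compounds named here, the one measured step that bears here is a number 20.3 percentage points lower from compound 1 to compound 2 (beyond the scatter), where the protected chain was added. Compound 3 `CC(C)[C@H](NC(=O)CN(c1ncnc2c1ncn2C1CCCCO1)C1CC1)C(=O)OCc1ccccc1` reverses that kind of change: isopropyl in place of 4-((tert-butoxycarbonyl)amino)butyl on a saturated chain carbon bound to an amide-type nitrogen and a carbonyl carbon. Removing the same chain is therefore expected to raise the read-out by a comparable amount, so a step of a number 17.3 percentage points higher from compound 2 to compound 3 (beyond the scatter) is expected. Compound 3 is estimated at 50%, within 30% to 68%.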

Compound 3, a percentage reported as activity, at one dose (the size of the read-out at that dose, not a potency): 34.9%
For compound 3 the middle estimate is 15.1 percentage points above the measured one, within the range that was stated.
By their numbers in this assay, from the lowest: compounds 2 and 3 (each within the scatter of the next); then compound 1.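

In this assay, isopropyl in place of the 4-((tert-butoxycarbonyl)amino)butyl chain gives a number 2.2 percentage points higher from compound 2 to compound 3 (within the scatter) and so does not recover the read-out of compound 1. With isopropyl in place of methyl, the same position shows a number 18.1 percentage points lower from compound 1 to compound 3 (beyond the scatter), so a drop beyond the scatter occurs here without the protected chain. No supporting data explain this result.

Among the compounds shown, only methyl holds the higher read-out. Open, on these data alone, is whether ethyl, or a free amine at the end of the butyl chain, would read like methyl or like isopropyl.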